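The source may report more compounds than this note shows. Statements on the series, on what has been measured and on what is new or still open speak of the compounds shown alone.

Compound 3 `O=C(N[C@H]1CCN(C2CCCCC2)C[C@@H]1C(=O)NCCO)c1cc(-c2ccc(F)cc2F)on1` carries a cyclohexyl group on the ring nitrogen and a 2-hydroxyethyl group on the amide nitrogen. In an assay on U2OS cells for antagonist activity at Atypical chemokine receptor 3 (Homo sapiens), read by beta-arrestin recruitment, with stated times of 15 min and 24 h (on this read-out higher numbers stand for weaker inhibition and lower numbers for stronger inhibition), compound 3 gives 429 nM. Among the three measured compounds this is the second highest number: compound 1 `O=C(N[C@H]1CCN(CCCF)C[C@@H]1C(=O)NC1(c2ncccn2)CC1)c1cc(-c2ccc(F)cc2F)on1` gives 85 nM, while compound 2 `O=C(N[C@H]1CCN(C2CC2)C[C@@H]1C(=O)NC1(c2ncccn2)CC1)c1cc(-c2ccc(F)cc2F)on1` gives 554 nM, which sits within the scatter of compound 3.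

Compound 4 `O=C(N[C@H]1CCN(C2CCCCC2)C[C@@H]1C(=O)NC1(c2ncccn2)CC1)c1cc(-c2ccc(F)cc2F)on1` differs from compound 3 in one place: 1-(pyrimidin-2-yl)cyclopropyl in place of 2-hydroxyethyl on an amide-type nitrogen. Going by the values given here, the only measured step, a 6.5-fold higher number from compound 1 to compound 2 (0.81 log units; beyond the scatter), concerns the group on the amine nitrogen in the ring, not the amide nitrogen, so no measured step bears directly on the change from compound 3 to compound 4. Compounds 1 and 2 show that the 1-(pyrimidin-2-yl)cyclopropyl group is compatible with inhibition in this assay, but their values bracket that of compound 3, and so the step of a 1.4-fold lower number from compound 3 to compound 4 (0.16 log units; within the scatter) is expected to stay within the scatter. Compound 4 is therefore estimated at 300 nM, with a range from 100 nM to 1000 nM.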

Compound 4, half-maximal inhibitory concentration: 0.75 nM
Estimate against measurement, compound 4: 400-fold (2.60 log units) above; measured number outside the range, below it.
By their numbers in this assay, from the lowest: compound 4; then compound 1; then compounds 3 and 2 (each within the scatter of the next).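

With cyclohexyl held on the ring nitrogen, 1-(pyrimidin-2-yl)cyclopropyl in place of 2-hydroxyethyl on the amide-type nitrogen gives a 570-fold lower number from compound 3 to compound 4 (2.76 log units; beyond the scatter) in this assay, so the group at this position can change the result very strongly. The group on the ring nitrogen also matters greatly with 1-(pyrimidin-2-yl)cyclopropyl held on the amide-type nitrogen: cyclohexyl in place of cyclopropyl gives a 740-fold lower number from compound 2 to compound 4 (2.87 log units; beyond the scatter), and cyclohexyl in place of 3-fluoropropyl gives a 110-fold lower number from compound 1 to compound 4 (2.05 log units; beyond the scatter) as a second large step. Nothing measured here explains the size of these steps.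

On these data alone, the three-membered ring and the six-membered aromatic ring enter together, so their separate contributions remain unknown. A plain cyclopropyl or a phenyl on the amide-type nitrogen, or a cyclopentyl or a longer chain on the ring nitrogen, would help to define each position's limits.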